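Methyl on a Saturated Ring Carbon: Cytotoxicity Unchanged

A few compounds are considered here, and "the series" means these few. Any claim that something is new, unique, unknown or untested is made for them only; others in the source may bear on it.

Measured compounds:
compound 1 `Clc1ccc(C2ON=C(c3ccccc3Cl)O2)cc1`, > 100000 nM
compound 2 `CC1(c2ccc(Cl)cc2)ON=C(c2ccccc2Cl)O1`, > 100000 nM
compound 3 `Clc1ccc(C2ON=C(c3cccc(Cl)c3)O2)cc1`, > 100000 nM

In an ADME assay on HEK293 cells (Homo sapiens) for cytotoxicity, read by MTT assay, with a stated time of 44 h (a lower number here means a stronger inhibitor, a higher number a weaker inhibitor), compound 1 gives only a limit, > 100000 nM. Compound 2 likewise gives only a limit in this assay, > 100000 nM. Compound 2 arises from compound 1 by methyl in place of hydrogen on a saturated ring carbon, and the step that the two limits leave unreadable from compound 1 to compound 2 cannot be read because of the limit of > 100000 nM in this assay, at which 3 of the 3 values shown sit. The difference between the core of compound 1 and the core of compound 3 is not broken down here. Compound 3 gives only a limit in this assay, > 100000 nM.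

Compound 4 `CC1(c2ccc(Cl)cc2)ON=C(c2cccc(Cl)c2)O1` has not been measured. It arises from compound 3 by methyl in place of hydrogen on a saturated ring carbon, the same change as that from compound 1 to compound 2. The expected step in this assay is a step that the limit leaves unreadable from compound 3 to compound 4; that expectation rests on compound 1 and compound 2 both sitting at the limit of > 100000 nM in this assay, at which 3 of the 3 values shown sit. Compound 4 is therefore estimated at 150000 nM, expected between 60000 nM and 500000 nM.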

Compound 4, half-maximal inhibitory concentration: > 100000 nM
Compound 4: no number, only a limit; the forecaster's own chance of this, stated with the estimate: 85%; the middle value lies beyond the limit too.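

No step can be read from compound 3 to compound 4, because each gives only a limit: the limit of > 100000 nM in this assay, at which 4 of the 4 values shown sit. The compounds shown leave open whether methyl in place of hydrogen on a saturated ring carbon changes the read-out at all.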